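A few compounds are considered here, and "the series" means these few. Any claim that something is new, unique, unknown or untested is made for them only; others in the source may bear on it.

Of the compounds shown here, three sharing one core have been tested in a functional assay on KM12 cells (Homo sapiens) for inhibition, read by sulforhodamine B assay, with a stated time of 48 h, tested at 10 uM; on this read-out lower numbers stand for less inhibition and higher numbers for more inhibition at the one concentration tested (going by the name of the read-out). Compound 1, `Brc1cn2ccnc2c(-c2ccc3ncn(C4CCCCC4)c3c2)n1`, gives 67.7%. Compound 2, `COc1ccc(-c2cn3ccnc3c(-c3ccc4ncn(C5CCCCC5)c4c3)n2)cc1`, gives 83.2%. Compound 3, `CC(=O)c1ccc(-c2cn3ccnc3c(-c3ccc4ncn(C5CCCCC5)c4c3)n2)cc1`, gives 11.7%, the lowest of the three numbers; its nearest neighbour is compound 1 and its furthest is compound 2, both well beyond the scatter.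

The step now taken leads to compound 4, `c1csc(-c2cn3ccnc3c(-c3ccc4ncn(C5CCCCC5)c4c3)n2)c1`, with the change (thiophen-2-yl in place of 4-acetylphenyl on an aromatic carbon).

Going by the values given here, two measured steps bear on this. Replacing bromo with 4-acetylphenyl gave a number 56 percentage points lower from compound 1 to compound 3 (beyond the scatter), and replacing methoxy with acetyl on the aryl ring gave a number 71.5 percentage points lower from compound 2 to compound 3 (beyond the scatter). Both show that the presence of 4-acetylphenyl goes together with markedly less inhibition, whereas the step of a number 15.5 percentage points higher from compound 1 to compound 2 (beyond the scatter) shows a modest gain when a different aryl group enters. Removing 4-acetylphenyl in compound 4 is therefore expected to raise the read-out substantially, though thiophen-2-yl has no direct precedent among these compounds, so the exact level is uncertain.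

For compound 4 in this assay the expected value is 60%, with a range from 30% to 85%, an expected step of a number 48.3 percentage points higher from compound 3 to compound 4 (beyond the scatter).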

Compound 4, a percentage reported as inhibition, at one concentration (the size of the read-out at that concentration, not a potency): 4.89%
Compound 4: middle estimate off by 55.1 percentage points, on the high side; the measured number lies below the stated range.
By their numbers in this assay, from the lowest: compounds 4 and 3 (each within the scatter of the next); then compound 1; then compound 2.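

In this assay, thiophen-2-yl and 4-acetylphenyl cannot be told apart at this aromatic carbon, as the step of a number 6.8 percentage points lower from compound 3 to compound 4 (within the scatter) shows, so taking away 4-acetylphenyl does not by itself bring inhibition back. The thiophen-2-yl compound also falls far short of the other two, with a number 78.3 percentage points lower from compound 2 to compound 4 (beyond the scatter) against the 4-methoxyphenyl compound and a number 62.8 percentage points lower from compound 1 to compound 4 (beyond the scatter) against the bromo compound, which means that a new aromatic ring at this place does not in itself carry a high number: compound 3 and compound 4 both have one and stay low, while compound 2 goes against them and stays high. No measurement available here explains why these ring groups differ so sharply.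

Going by these compounds alone, with only three ring groups at this place, it remains open whether the high number of compound 2 depends on the methoxy group itself, or whether an amine, a hydroxyl or a longer ether chain such as ethoxy on the same phenyl ring would keep it. A plain phenyl ring would help to separate the effect of the ring from that of the group it carries, and a carboxylic acid there would test a quite different kind of group at the same place.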